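The compounds below may be only part of what the source reports. "The series", "measured", "known", "first", "only" and "open" are said of these compounds alone.

Measured so far in a functional assay on the whole organism (strain Wistar) for inhibition, with Rattus norvegicus as the target, read by paw edema, with stated times of 3 h and 1 h, at a dose of 6 mg/kg by the oral route; a lower number here means less inhibition, a higher number more inhibition at the dose given (going by the name of the read-out):
Compound 1, `O=C(CO[N+](=O)[O-])NNC(=O)c1ccc(-n2[nH]c(=O)cc2-c2ccc([N+](=O)[O-])cc2)cc1`, gives 24%.
Compound 2, `COc1ccccc1-c1cc(=O)[nH]n1-c1ccc(C(=O)NNC(=O)CO[N+](=O)[O-])cc1`, gives 57.9%.
Compound 3, `CCOC(=O)c1c(-c2ccc([N+](=O)[O-])cc2)n(-c2ccc(C(=O)NNC(=O)CO[N+](=O)[O-])cc2)[nH]c1=O`, gives 22.2%.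

Compound 3 stands lowest of the three numbers. Its nearest neighbour is compound 1, whose number is higher only by a margin within the scatter, so the two cannot be told apart; the furthest is compound 2, whose number lies beyond the scatter above it. Compound 4, `CCOC(=O)c1c(-c2ccccc2OC)n(-c2ccc(C(=O)NNC(=O)CO[N+](=O)[O-])cc2)[nH]c1=O`, has not yet been measured. It differs from compound 3 in one place: 2-methoxyphenyl in place of 4-nitrophenyl on an aromatic carbon.

Going by the values given here, one measured step bears directly on this change. The same swap of groups, made on the core of compound 1 to give compound 2, gave a number 33.9 percentage points higher from compound 1 to compound 2 (beyond the scatter) in this assay. The other step, a number 1.8 percentage points lower from compound 1 to compound 3 (within the scatter), shows that adding the ethoxycarbonyl group hardly moved the number, so compound 3 starts from about the same place as compound 1. A step of similar size and the same direction is therefore expected from compound 3 to compound 4, that is a number 31.8 percentage points higher from compound 3 to compound 4 (beyond the scatter). Compound 4 is thus estimated at 54% in this assay, with an expected range from 36% to 70%.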

Compound 4, a percentage reported as inhibition, in the whole organism at one dose (the size of the read-out at that dose, not a potency): 25.1%
Compound 4: the middle estimate sits 28.9 percentage points above what was measured; the measured number lies below the stated range.
By their numbers in this assay, from the lowest: compounds 3, 1 and 4 (each within the scatter of the next); then compound 2.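

In this assay, the change from 4-nitrophenyl to 2-methoxyphenyl on this aromatic carbon gives a number 2.9 percentage points higher from compound 3 to compound 4 (within the scatter), so on the core bearing ethoxycarbonyl it has no readable effect, and what it does depends on the core that carries it: the same change on two cores in this assay, a number 33.9 percentage points higher (beyond the scatter) from compound 1 to compound 2 and a number 2.9 percentage points higher (within the scatter) from compound 3 to compound 4, 31 percentage points apart, beyond the scatter of two such steps

Ethoxycarbonyl depends on its partner in the same way, giving a number 32.8 percentage points lower from compound 2 to compound 4 (beyond the scatter) when 2-methoxyphenyl is present, whereas its step with 4-nitrophenyl present stayed within the scatter: the same change on two cores in this assay, a number 1.8 percentage points lower (within the scatter) from compound 1 to compound 3 and a number 32.8 percentage points lower (beyond the scatter) from compound 2 to compound 4, 31 percentage points apart, beyond the scatter of two such steps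

Among these four compounds, only compound 2, which combines 2-methoxyphenyl with hydrogen where the others in this comparison have ethoxycarbonyl or 4-nitrophenyl, stands apart from the rest, so the two changes do not simply add up and neither group can be given a fixed contribution of its own.

The compounds shown leave open whether a methyl group or a carboxylic acid in place of ethoxycarbonyl would also remove the gain that goes with 2-methoxyphenyl. They also leave open whether another ring, such as plain phenyl or 4-methoxyphenyl, would behave like 2-methoxyphenyl on either core.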